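A few compounds are considered here, and "the series" means these few. Any claim that something is new, unique, unknown or untested is made for them only; others in the source may bear on it.

Working notes on the series.

Two compounds have been run in an assay on HEK293 cells for inhibition of Voltage-dependent T-type calcium channel subunit alpha-1G (Homo sapiens), read by patch clamp; a lower number here means a stronger inhibitor, a higher number a weaker inhibitor. Compound 1 `CCCc1nc(-c2ccccc2)c(CNCCCN2CCN(c3cccc(F)c3)CC2)o1` gives 3030 nM, the lowest of the two numbers measured. Compound 2 `CCCc1nc(-c2ccccc2)c(CNCCN2CCN(C(c3ccccc3)c3ccccc3)CC2)o1` gives 7470 nM; the gap between compound 1 and compound 2 lies beyond the usual scatter, though the two structures differ in more than one place, so the gap is not assigned to any single change.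

Compound 3 `CCCc1nc(-c2ccccc2)c(CNCCCN2CCN(c3ccc(C)c(C)c3)CC2)o1` has not yet been measured in this assay. It differs from compound 1 in a single place: 3,4-dimethylphenyl in place of 3-fluorophenyl on an amine nitrogen in a ring. The ring that carries the change, the six-membered non-aromatic ring with 2 nitrogen, is otherwise kept, as is the shared core and the chain that links them.

For the measured compounds named here, no measured pair isolates this change, so its size is unknown. The expectation is for a small step from compound 1 to compound 3 in this assay, a 1.2-fold lower number from compound 1 to compound 3 (0.08 log units; within the scatter), at most a modest gain and quite possibly none beyond the scatter. On that basis compound 3 is estimated at 2500 nM, with a likely range from 900 nM to 7000 nM.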

Compound 3, half-maximal inhibitory concentration: 3020 nM
Beside the measured number, compound 3's estimate is 1.2-fold (0.08 log units) below it, and the stated range covers the measured number.
By their numbers in this assay, from the lowest: compounds 3 and 1 (each within the scatter of the next); then compound 2.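

In this assay, for the compounds shown here, the step of a 1.0-fold lower number from compound 1 to compound 3 (0.00 log units; within the scatter) is the first comparison that isolates a single change, and it lies within the scatter. On an amine nitrogen in a ring, 3,4-dimethylphenyl and 3-fluorophenyl therefore cannot be told apart in this assay, even though the entering group carries only carbon where the leaving group carries a fluorine, and has one more heavy atom. Nothing in the data bears on why the two groups read alike.

This single pair says nothing about how far the position tolerates other kinds of group, such as a pyridine ring, a methoxy-substituted phenyl or an unsubstituted phenyl on the same nitrogen, so the result cannot be extended beyond these two aryl groups. The gap to compound 2 also stays unassigned, since compound 2 differs from both compound 1 and compound 3 in more than one place, leaving the separate contributions of the chain that links the core to the ring and of the diphenylmethyl group open.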